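Pyrazole ester prodrug: half-life after a ring substitution

This account rests on a few compounds, and the source may have more. Where it says the series, first, only, none or still open, it means among the compounds named here.

Measured compounds: compound 1 `CCc1cc(C(=O)OCO[P@@]2(=O)OCC(C)(C)[C@H](C(=O)NCCC(=O)OC)O2)n(C)n1`; compound 2 `COC(=O)CCNC(=O)[C@@H]1O[P@](=O)(OCOC(=O)c2scnc2C)OCC1(C)C`; compound 3 `CC(C)(C)C(=O)OCO[P@@]1(=O)OCC(C)(C)[C@H](C(=O)NCCC(=O)OC2CCN(Cc3ccccc3)C2)O1`.

In an ADME assay on blood (Homo sapiens) for pharmacokinetics (a higher number here means that the compound lasts longer, a lower number that the compound disappears faster), compound 1 gives >= 0.97 h, which is a limit of the assay rather than a number (the limit of >= 0.97 h in this assay, at which 1 of the 3 values shown sits). In this assay compound 2 gives < 0.16 h, also a limit (the limit of < 0.16 h in this assay, at which 1 of the 3 values shown sits). Compound 3 gives 0.19 h. Compound 1 thus stands at the upper limit among the three values shown, while compound 2 and compound 3 sit at or near the lower end.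

Compound 4 `COC(=O)CCNC(=O)[C@@H]1O[P@@](=O)(OCOC(=O)c2cc(C(C)(C)C)n[nH]2)OCC1(C)C` differs from compound 1 by 3-(tert-butyl)-1H-pyrazol-5-yl in place of 3-ethyl-1-methyl-1H-pyrazol-5-yl on a carbonyl carbon. Among the measured compounds shown here, no step between measured compounds shows this change. A moderate decrease is expected, with an at least 1.6-fold lower number from compound 1 to compound 4 (0.20 log units; that floor lies within the scatter), so compound 4 is estimated at 0.6 h, between 0.2 h and 1.5 h.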

Compound 4, half-life: > 1 h
Compound 4: a limit, no number (the forecaster's own chance of this, stated with the estimate: 30%); middle value at least 1.6-fold (0.22 log units) from the limit.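

Compound 1 and compound 4 both carry only limits in this assay, and the step between them cannot be read. The compounds shown leave open whether 3-(tert-butyl)-1H-pyrazol-5-yl in place of 3-ethyl-1-methyl-1H-pyrazol-5-yl changes the half-life at all.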